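Swapping a Fluorophenyl for an Iodophenyl on the Carbonyl

The compounds below may be only part of what the source reports. "The series", "measured", "known", "first", "only" and "open" are said of these compounds alone.

Of the compounds shown here, three sharing one core have been measured in a functional assay on HepG2 cells (Homo sapiens) for inhibition, read by MTT assay; on this read-out lower numbers stand for stronger inhibition and higher numbers for weaker inhibition. Compound 1 `COc1cc2ncnc(Nc3ccc(NC(=O)c4ccc(C)cc4)cc3)c2cc1OC` gives 25000 nM, compound 2 `COc1cc2ncnc(Nc3ccc(NC(=O)c4cccc(F)c4)cc3)c2cc1OC` gives 8200 nM, and compound 3 `COc1cc2ncnc(Nc3ccc(NC(=O)c4ccc(F)cc4)cc3)c2cc1OC` gives 15000 nM. On these numbers compound 3 holds the second highest place, yet a 1.7-fold lower number from compound 1 to compound 3 (0.22 log units; within the scatter) and a 1.8-fold higher number from compound 2 to compound 3 (0.26 log units; within the scatter) both stay within the scatter, so compound 3 is not separated from either neighbour. Only a 3.0-fold lower number from compound 1 to compound 2 (0.48 log units; beyond the scatter) reaches beyond the scatter.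

Compound 4 `COc1cc2ncnc(Nc3ccc(NC(=O)c4ccccc4I)cc3)c2cc1OC` is not yet measured. Its difference from compound 3 is 2-iodophenyl in place of 4-fluorophenyl on a carbonyl carbon. Going by the values given here, no measured step places an iodine on that ring; the nearest comparisons are a 1.8-fold higher number from compound 2 to compound 3 (0.26 log units; within the scatter), which shows no difference beyond the scatter between the two fluorine placements, and a 1.7-fold lower number from compound 1 to compound 3 (0.22 log units; within the scatter), which shows that exchanging the group itself was also of small consequence. From this the step of a 1.3-fold lower number from compound 3 to compound 4 (0.10 log units; within the scatter) is expected to be small, with wide uncertainty in either direction. Compound 4 is therefore estimated at 12000 nM, with a range from 3500 nM to 40000 nM.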

Compound 4, half-maximal inhibitory concentration: 33000 nM
Beside the measured number, compound 4's estimate is 2.8-fold (0.44 log units) below it; the range from low to high includes it.
By their numbers in this assay, from the lowest: compounds 2, 3, 1 and 4 (each within the scatter of the next, the first and the last beyond it).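

In this assay, the change on the carbonyl carbon now separates compound 3 from another compound, with a 2.2-fold higher number from compound 3 to compound 4 (0.34 log units; beyond the scatter) as the result of placing 2-iodophenyl where 4-fluorophenyl stood. The position therefore responds to this exchange, and a 4.0-fold higher number from compound 2 to compound 4 (0.60 log units; beyond the scatter) is the widest step among the four compounds, while a 1.3-fold higher number from compound 1 to compound 4 (0.12 log units; within the scatter) leaves 2-iodophenyl and 4-methylphenyl unseparated at this position. No measurement shown here gives a reason for these steps.

From the compounds shown here alone, the exchange alters both the halogen and its place on the ring, so it remains open which of the two carries the step; 2-fluorophenyl and 4-iodophenyl on the same carbonyl carbon would separate them. Also open, going by these compounds, is how this read-out would respond to an amine or a carboxylic acid on that ring.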